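The source may hold more compounds than are shown below. What is called first, only, known or untested is meant among the compounds shown, and "the series" means these compounds.

Measured in an ADME assay on MT4 cells (Homo sapiens) for cytotoxicity, read by MTT assay; a higher number here means that more compound is tolerated, a lower number that less compound is tolerated:
Compound 1 `O=C(CSc1nncnc1-c1cccc2ccccc12)Nc1ccccc1[N+](=O)[O-]`: 142000 nM
Compound 2 `O=C(CSc1nncnc1-c1ccccc1Cl)c1ccc(Cl)c(Cl)c1`: 33000 nM
Compound 3 `O=C(CSc1nncnc1-c1ccccc1Cl)Nc1ccccc1`: 127000 nM

Compound 1 and compound 3 lie within the scatter of each other, and compound 2 gives the lowest number of the three. Compound 4 `Cc1ccccc1NC(=O)CSc1nncnc1-c1cccc2ccccc12` departs from compound 1 at one place, with methyl in place of nitro on an aromatic carbon. Going by the values given here, no measured step makes this swap. Among the compounds with values here, the only step available, a 3.8-fold higher number from compound 2 to compound 3 (0.59 log units; beyond the scatter), is a modest one and concerns a different change on the carbonyl. Compound 3, which carries no nitro, still gives 127000 nM, so no shift beyond the scatter is expected in this assay. The expected step is a 1.2-fold lower number from compound 1 to compound 4 (0.07 log units; within the scatter). Compound 4 is estimated at 120000 nM, within an expected range of 60000 nM to 240000 nM.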

Compound 4, half-maximal cytotoxic concentration: 158000 nM
For compound 4 the middle estimate is 1.3-fold (0.12 log units) below the measured one, within the range that was stated.
By their numbers in this assay, from the lowest: compound 2; then compounds 3, 1 and 4 (each within the scatter of the next).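

In this assay, going by these compounds alone, methyl in place of nitro on an aromatic carbon, ortho to a large group, gives a 1.1-fold higher number from compound 1 to compound 4 (0.05 log units; within the scatter) and is the first direct reading of this change. At this place, then, going from 2-nitrophenyl to 2-methylphenyl removes both hydrogen-bond acceptors of the nitro group and leaves the tolerated concentration within the scatter. Nothing shown explains this tolerance. From the compounds shown here alone, whether an amine or a carboxylic acid on this carbon would behave the same stays open, as does whether this swap would read the same on a different core.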